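Urea series in zebrafish: aryl to benzyl on the urea nitrogen

The source may report more compounds than this note shows. Statements on the series, on what has been measured and on what is new or still open speak of the compounds shown alone.

Measured so far:
compound 1 `CCN1CCc2c(sc(NC(=O)Nc3ccc(Br)cc3)c2C(N)=O)C1`: 3130 nM
compound 2 `CCN1CCc2c(sc(NC(=O)Nc3cccc(C#N)c3)c2C(N)=O)C1`: 10300 nM

Among the compounds with values here, in a functional assay (strain AB) with Danio rerio as the target, read by microscopy, with a stated time of 1 h (on this read-out higher numbers stand for an effect only at larger amounts of compound and lower numbers for an effect already at smaller amounts), compound 2 stands highest of the two numbers; the one measured step, a 3.3-fold higher number from compound 1 to compound 2 (0.52 log units; beyond the scatter), lies beyond the scatter. Compound 3 `CCN1CCc2c(sc(NC(=O)NCc3cccc(Cl)c3)c2C(N)=O)C1` differs from compound 2 by 3-chlorobenzyl in place of 3-cyanophenyl on an amide-type nitrogen. Within the data shown here, that step is the only comparison at this nitrogen, and no measured pair swaps an aryl for a benzyl, so it bears only loosely here. Compound 3 is expected at 5000 nM (range 1500 nM to 20000 nM), a step of a 2.1-fold lower number from compound 2 to compound 3 (0.31 log units; beyond the scatter) being the expected outcome, with wide uncertainty.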

Compound 3, half-maximal effective concentration: > 25000 nM
Compound 3: only a limit was reported; the forecaster's own chance of this, stated with the estimate: 10%; middle value at least 5.0-fold (0.69 log units) from the limit.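

In this assay, moving from an aryl to a benzyl group on this amide-type nitrogen shifts the series towards larger amounts: an at least 2.4-fold higher number from compound 2 to compound 3 (0.38 log units; beyond the scatter), and an at least 7.9-fold higher number from compound 1 to compound 3 (0.90 log units; beyond the scatter). Both aryl ureas, compound 1 and compound 2, therefore act at smaller amounts than the benzyl urea, compound 3. For compound 3 only a limit is reported, so the full size of both steps stays unknown: the limit of > 25000 nM in this assay, at which 1 of the 3 values shown sits.

Compound 3 changes both the link to the ring and the ring substituent, so the two effects cannot be separated. Unsubstituted benzyl, 3-cyanobenzyl and 3-chlorophenyl on this nitrogen would separate them.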